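Indolyl in place of biphenyl in the ester series, cytotoxicity

The source may hold more compounds than are shown below. What is called first, only, known or untested is meant among the compounds shown, and "the series" means these compounds.

The series rests on compound 1 `CC(C)N(Cc1cccc(OCCCCCC(=O)O)c1)C(=O)c1ccc(-c2cccc(-c3ccccc3)c2)cc1`, its ethyl ester compound 2 `CCOC(=O)CCCCCOc1cccc(CN(C(=O)c2ccc(-c3cccc(-c4ccccc4)c3)cc2)C(C)C)c1`, and the benzyloxy analogue compound 3 `CCOC(=O)CCCCCOc1cccc(CN(C(=O)c2ccc(-c3cccc(OCc4ccccc4)c3)cc2)C(C)C)c1`. In an ADME assay on BJ cells (Homo sapiens) for cytotoxicity, read by CellTiter-Glo and resazurin assay, with a stated time of 72 h (on this read-out higher numbers stand for an effect only at larger amounts of compound and lower numbers for an effect already at smaller amounts), compound 1 gives only a limit, > 26000 nM. In this assay compound 2 likewise gives only a limit, > 26000 nM. In this assay compound 3 again gives only a limit, > 26000 nM. Compound 2 therefore stands at a limit rather than at a number, and the two other values shown are limits too, all three sitting at the same point (the limit of > 26000 nM in this assay, at which 3 of the 3 values shown sit). The step that the two limits leave unreadable from compound 1 to compound 2 and the step that the two limits leave unreadable from compound 2 to compound 3 are both unreadable for this reason.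

Compound 4 `CCOC(=O)CCCCCOc1cccc(CN(C(=O)c2ccc(-c3ccc4[nH]ccc4c3)cc2)C(C)C)c1` differs from compound 2 by 1H-indol-5-yl in place of 3-phenylphenyl on an aromatic carbon. The two measured steps bear on this change only in that neither the ester change nor the benzyloxy change moved any compound off the limit, so no step beyond the scatter is expected in this assay for compound 4 either, in neither direction, and the step from compound 2 to compound 4 is estimated as a step that the limit leaves unreadable from compound 2 to compound 4. Compound 4 is therefore expected to give about 30000 nM in this assay, within 10000 nM to 100000 nM, most likely again as a limit.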

Compound 4, half-maximal effective concentration: > 26000 nM
Compound 4: only a limit was reported; the forecaster's own chance of this, stated with the estimate: 80%; the middle value lies beyond the limit too.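

In this assay compound 4 gives > 26000 nM as a limit and not a number. Compound 2 also stands at a limit, so no new step can be read between compound 2 and compound 4. The compounds shown leave open where in this assay any of them would reach a half-maximal effect, and whether the 3-phenylphenyl, 1H-indol-5-yl and benzyloxy groups differ at all on this read-out.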